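Swapping 1H-pyrazol-1-yl for tert-butoxy on the side chain

A few compounds are considered here, and "the series" means these few. Any claim that something is new, unique, unknown or untested is made for them only; others in the source may bear on it.

- compound 1 `CC(C)(C)[C@@H](O)C(=O)N1C[C@@H]2C[C@@H]2[C@H]1C(=O)NCc1cc(Cl)ccc1-n1cnnn1`: 570 nM
- compound 2 `O=C(NCc1cc(Cl)ccc1-n1cnnn1)[C@@H]1[C@H]2C[C@H]2CN1C(=O)[C@H](O)C1CCCCC1`: 850 nM
- compound 3 `O=C(NCc1cc(Cl)ccc1-n1cnnn1)[C@@H]1[C@H]2C[C@H]2CN1C(=O)[C@H](O)Cn1cccn1`: 1800 nM

All three values come from a functional assay on a cell-free system (plasma, Homo sapiens), with a stated time of 3 min; a higher number here means a weaker inhibitor, a lower number a stronger inhibitor. Compound 3 has the highest number of the three, which makes it the weakest inhibitor in this small set. Two steps lead up to it: a 2.1-fold higher number from compound 2 to compound 3 (0.33 log units; beyond the scatter) and a 3.2-fold higher number from compound 1 to compound 3 (0.50 log units; beyond the scatter).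

The next compound, compound 4 `CC(C)(C)OC[C@@H](O)C(=O)N1C[C@@H]2C[C@@H]2[C@H]1C(=O)NCc1cc(Cl)ccc1-n1cnnn1`, keeps the shared core and changes one group: tert-butoxy in place of 1H-pyrazol-1-yl on a saturated chain carbon, two bonds along the chain from a carbonyl carbon and an oxygen on a saturated carbon. Read one bond further out, this is (1H-pyrazol-1-yl)methyl to (tert-butoxy)methyl.

Within the data shown here, no measured compound carries tert-butoxy, so any forecast is an extrapolation. The closest guide is compound 1, whose tert-butyl group also appears within tert-butoxy, and its step to the pyrazole compound is a 3.2-fold higher number from compound 1 to compound 3 (0.50 log units; beyond the scatter). Compound 1 and compound 2 cannot be told apart, as a 1.5-fold higher number from compound 1 to compound 2 (0.17 log units; within the scatter) shows. Compound 3 therefore looks like the outlier, and a move towards a lower number in this assay is expected, of about the size of the two steps above. The expected change is a 2.1-fold lower number from compound 3 to compound 4 (0.33 log units; beyond the scatter). For compound 4 the estimated value is 850 nM, with an expected range of 350 nM to 2000 nM.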

Compound 4, half-maximal inhibitory concentration: 570 nM
For compound 4 the middle estimate is 1.5-fold (0.17 log units) above the measured one; the measured number falls inside the stated range.
By their numbers in this assay, from the lowest: compounds 1, 4 and 2 (each within the scatter of the next); then compound 3.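

In this assay tert-butoxy and 1H-pyrazol-1-yl both have 5 heavy atoms, yet the swap gives a 3.2-fold lower number from compound 3 to compound 4 (0.50 log units; beyond the scatter) and so the number at this position depends on more than the heavy-atom count of the group. The other two steps read a 1.5-fold lower number from compound 2 to compound 4 (0.17 log units; within the scatter) and no change at the digits printed from compound 1 to compound 4 (within the scatter) and both lie within the scatter, so (tert-butoxy)methyl, cyclohexyl and tert-butyl cannot be told apart here, and compound 3 alone stands apart from the rest. No measurement beyond these inhibition numbers bears on why the pyrazole compound differs from the others.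

Among these compounds, only one aromatic ring appears at this place, so a phenyl ring or a 1H-imidazol-1-yl group would be needed to tell whether the higher number of compound 3 goes with aromatic rings in general or with this particular ring. An amine or a carboxylic acid on the same chain, or a longer chain ending in tert-butoxy, would show how widely the similar numbers of compounds 1, 2 and 4 hold.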